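Bromo to Propyl on a Benzamide Antiproliferative

The source may hold more compounds than are shown below. What is called first, only, known or untested is meant among the compounds shown, and "the series" means these compounds.

Compound 1 `O=C(/C=C/c1ccc(COc2ccccc2)cc1)NO` gives 8400 nM in a functional assay on HepG2 cells (Homo sapiens) for antiproliferative activity, read by CCK-8 assay, with a stated time of 72 h; on this read-out lower numbers stand for stronger inhibition and higher numbers for weaker inhibition.
Compound 2 `Nc1ccccc1NC(=O)c1ccc(COc2ccc(Br)cc2)cc1` gives > 32000 nM in this assay.
Compound 3 `O=C(/C=C/c1ccc(CN2CCc3ccccc32)cc1)NO` gives 14900 nM in this assay.

The value for compound 2 is a limit of this assay, not a measured number. Compound 2 therefore stands at the edge of what the measurement can report, as the limit of > 32000 nM in this assay, at which 1 of the 3 values shown sits, describes, while compound 1 and compound 3 each give a number.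

Compound 4 `CCCc1ccc(OCc2ccc(C(=O)Nc3ccccc3N)cc2)cc1` is the next compound to be tested. It differs from compound 2 in one place: propyl in place of bromo on an aromatic carbon. Among the measured compounds shown here, no measured pair of compounds shows what this particular exchange does, so there is no measured step to lean on.

With compound 2 at the limit, the step in this assay is expected to be modest and its direction is uncertain, perhaps a slight gain in inhibition, perhaps none beyond the scatter. The expected step is an at least 1.6-fold lower number from compound 2 to compound 4 (0.20 log units; that floor lies within the scatter). Compound 4 is estimated at 20000 nM, within a range from 5000 nM to 80000 nM.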

Compound 4, half-maximal inhibitory concentration: 4750 nM
Compound 4: the middle estimate sits 4.2-fold (0.62 log units) above what was measured; measured number below the stated range.
By their numbers in this assay, from the lowest: compounds 4, 1 and 3 (each within the scatter of the next, the first and the last beyond it). At a limit, above all of these: compound 2.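

Exchanging 4-bromophenyl for 4-propylphenyl in this assay gives an at least 6.7-fold lower number from compound 2 to compound 4 (0.82 log units; beyond the scatter). Among the compounds shown here, this is the first measured sign that the group on this aromatic carbon, para to a large group, can change the antiproliferative read-out on the shared core, and that a chain of three carbon atoms in place of a single bromine is tolerated there. Compound 2 stands at a limit, so this step gives only a lower bound on the true difference: the limit of > 32000 nM in this assay, at which 1 of the 4 values shown sits.

With only bromo and propyl shown at this place, two points cannot yet tell whether the gain comes from adding propyl or from removing bromo. A compound with hydrogen, an amine or a longer chain such as butyl at this place would show whether the number keeps falling or turns back up.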